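This account rests on a few compounds, and the source may have more. Where it says the series, first, only, none or still open, it means among the compounds named here.

In an assay on CHO cells for inhibition of sodium channel protein type 2 subunit alpha (Homo sapiens) (on this read-out lower numbers stand for stronger inhibition and higher numbers for weaker inhibition), compound 1 `Cc1ccc(C(=O)NC(=N)N(C)Sc2cccc(C)c2)cc1` gives 5440 nM. Compound 2 `Cc1ccc(C(=O)NC(=N)NCCCCc2ccccc2)cc1` gives 1140 nM in this assay, and compound 3 `Cc1ccc(C(=O)NC(=N)NCCCCCc2ccccc2)cc1` gives 2110 nM. Compound 2 stands at the low end of these three numbers: the step of a 1.9-fold higher number from compound 2 to compound 3 (0.27 log units; within the scatter) stays within the scatter, whereas the number of compound 1 is beyond the scatter of that of compound 2. Compound 4 `N=C(NCCCCc1ccccc1)NC(=O)c1ccc(Cl)c(Cl)c1` has not yet been measured. It differs from compound 2 by 3,4-dichlorophenyl in place of 4-methylphenyl on a carbonyl carbon, on the carbonyl side of the shared core. Among the measured compounds shown here, none of the measured steps touches that side: the only single-point step, a 1.9-fold higher number from compound 2 to compound 3 (0.27 log units; within the scatter), concerns the chain end, and compound 1 differs from compound 2 in several places at once, so its value offers no guide. For the measured compounds named here, with no bearing step, the expected step of a 1.1-fold lower number from compound 2 to compound 4 (0.06 log units; within the scatter) is small, in no set direction, and carries a wide range. Compound 4 is therefore estimated to give 1000 nM in this assay, expected to lie between 300 nM and 3500 nM.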

Compound 4, half-maximal inhibitory concentration: 7110 nM
Beside the measured number, compound 4's estimate is 7.1-fold (0.85 log units) below it; measured number outside the range, above it.
By their numbers in this assay, from the lowest: compounds 2 and 3 (each within the scatter of the next); then compounds 1 and 4 (each within the scatter of the next).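

In this assay the carbonyl side of the shared core proves not to be neutral: 3,4-dichlorophenyl in place of 4-methylphenyl on a carbonyl carbon gives a change beyond the scatter (a 6.2-fold higher number from compound 2 to compound 4 (0.79 log units; beyond the scatter)), toward weaker inhibition. The only earlier single-place change, at the chain end (a 1.9-fold higher number from compound 2 to compound 3 (0.27 log units; within the scatter)), stayed within the scatter, so this is the first such change shown to move the number beyond it. Nothing measured here accounts for the shift.

Going by these compounds, what a plain phenyl, a 4-chlorophenyl or a 4-methoxyphenyl would give on that carbonyl carbon remains open, and with it whether the higher number goes with both chlorine atoms together or with only one. Also open, on these data alone, is how the longer chain of compound 3 would behave alongside 3,4-dichlorophenyl.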